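Aryl tail variation on the shared core

This account rests on a few compounds, and the source may have more. Where it says the series, first, only, none or still open, it means among the compounds named here.

Compound 1 `O=C(CCCCC#Cc1ccccn1)c1ncc(-c2ccccn2)o1`, compound 2 `O=C(CCCCCCc1cccc2ccccc12)c1ncc(-c2ccccn2)o1` and compound 3 `O=C(CCCCCCc1ccccc1C(=O)O)c1ncc(-c2ccccn2)o1` share one core and differ only in the group carried at the end of the chain. In an assay for inhibition of Fatty-acid amide hydrolase 1 (Rattus norvegicus) (a lower number here means a stronger inhibitor, a higher number a weaker inhibitor), compound 2 gives 2.6 nM. Compound 1 gives 280 nM in this assay. For compound 3 this assay reports no number but only a limit, > 600 nM, so compound 3 stands at the limit of > 600 nM in this assay, at which 1 of the 3 values shown sits, and cannot be placed more closely than that. Compound 4 `O=C(CCCCCCc1cccc(Cl)c1Cl)c1ncc(-c2ccccn2)o1` has not yet been measured. It differs from compound 3 by 2,3-dichlorophenyl in place of 2-carboxyphenyl on a saturated chain carbon, six bonds along the chain from a carbonyl carbon. For the measured compounds named here, no step between two measured compounds is available to calibrate the size of this change, so the expectation rests on the three values themselves. Compound 2 shows that a carbon-only ring at this position on this chain can give 2.6 nM. Compound 4 is expected to move toward such a number, an estimated step of an at least 60-fold lower number from compound 3 to compound 4 (1.77 log units; beyond the scatter) that should lie well beyond the scatter. The estimate for compound 4 in this assay is 10 nM, with a range from 2 nM to 60 nM.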

Compound 4, inhibition constant: 0.9 nM
Estimate against measurement, compound 4: 11-fold (1.05 log units) above; measured number outside the range, below it.
By their numbers in this assay, from the lowest: compound 4; then compound 2; then compound 1. At a limit, above all of these: compound 3.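

In this assay, for the compounds shown here, the replacement of 2-carboxyphenyl by 2,3-dichlorophenyl gives an at least 660-fold lower number from compound 3 to compound 4 (2.82 log units; beyond the scatter), so a substituted phenyl tail on this chain can reach the low end of the series, which the earlier compounds showed only for the carbon-only ring of compound 2. Compound 3 is held only as a limit, so this step has a bound and no exact size: the limit of > 600 nM in this assay, at which 1 of the 4 values shown sits.

Two carbon-only tails on this chain now give low numbers, compound 2 with 2.6 nM and compound 4 with 0.9 nM.

The step from the carboxylic acid to the two chlorines changes both at once, and the compounds shown do not separate the loss of one from the gain of the other. Also open, as far as these compounds go, is how a phenyl tail carrying a single chlorine or an amine would read here, and how 2,3-dichlorophenyl would read on a longer chain.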